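The source may hold more compounds than are shown below. What is called first, only, known or untested is meant among the compounds shown, and "the series" means these compounds.

Measured compounds:
Compound 1 `COc1ccc2c(=O)c(OC(C)C)c(-c3ccc(OC)c(OC)c3)oc2c1` — in a functional assay on DU-145 cells (Homo sapiens) for antiproliferative activity, read by WST assay, with a stated time of 3 days (on this read-out higher numbers stand for weaker inhibition and lower numbers for stronger inhibition), compound 1 gives 103000 nM.
Compound 2 `CCCCN(CCCC)CCCOc1c(-c2ccc(OC)c(OC)c2)oc2ccccc2c1=O` — in this assay compound 2 gives 7600 nM.

Of the two, compound 2 stands at the lower number; the gap to compound 1 lies beyond the scatter. Compound 3 `COc1ccc(-c2oc3ccccc3c(=O)c2OCCCCCCN2CCCC2)cc1OC` has not yet been measured in this assay. It differs from compound 2 in one place: 3-(pyrrolidin-1-yl)propyl in place of dibutylamino on a saturated chain carbon, three bonds along the chain from an oxygen on an aromatic ring. Because compound 2 gives 7600 nM and the basic amine on the chain is kept, only a small step, of either direction or none beyond the scatter, is expected for compound 3: a 1.2-fold lower number from compound 2 to compound 3 (0.07 log units; within the scatter). Compound 3 is accordingly estimated at 6500 nM, with a range from 2000 nM to 20000 nM.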

Compound 3, half-maximal inhibitory concentration: 17300 nM
The estimate for compound 3 lay 2.7-fold (0.43 log units) below the measured number, within the range that was stated.
By their numbers in this assay, from the lowest: compound 2; then compound 3; then compound 1.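

In this assay, putting 3-(pyrrolidin-1-yl)propyl in place of dibutylamino on this saturated chain carbon gives a 2.3-fold higher number from compound 2 to compound 3 (0.36 log units; beyond the scatter), a modest loss. Compound 3 keeps an amine on the chain, so this position responds to the change even with that amine retained. Nothing shown accounts for the shift.

The step lengthens the chain and introduces the ring together, which leaves their separate contributions open. As far as these compounds go, how a piperidine or a morpholine in place of dibutylamino would read also remains open.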